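The source may report more compounds than this note shows. Statements on the series, on what has been measured and on what is new or still open speak of the compounds shown alone.

Of the compounds shown here, three built on one shared core have been measured. Compound 1 `CC(C)[C@H](NC(=O)CN(c1ncnc2c1ncn2C1CCCCO1)C1CC1)C(=O)OCc1ccccc1` gives 30.1% in a functional assay on the whole organism (Tail, strain ICR) with Mus musculus as the target, in the tail flick test, with a stated time of 90 min, at a dose of 25 umol/kg by the oral route; on this read-out lower numbers stand for a weaker effect and higher numbers for a stronger effect at the one dose given. Compound 2 `NC(=O)CC[C@H](NC(=O)CN(c1ncnc2c1ncn2C1CCCCO1)C1CC1)C(=O)OCc1ccccc1` gives 37.8% in this assay, and compound 3 `CC(C)(C)OC(=O)NCCCC[C@H](NC(=O)CN(c1ncnc2c1ncn2C1CCCCO1)C1CC1)C(=O)OCc1ccccc1` gives 32.9%. Among these three numbers compound 3 stands second highest, with compound 1 nearest to it and compound 2 furthest; yet a number 2.8 percentage points higher from compound 1 to compound 3 (within the scatter), a number 4.9 percentage points lower from compound 2 to compound 3 (within the scatter) and a number 7.7 percentage points higher from compound 1 to compound 2 (within the scatter) all lie within the scatter, so none of the three can be called stronger or weaker than another.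

Compound 4 `C[C@@H](O)[C@H](NC(=O)CN(c1ncnc2c1ncn2C1CCCCO1)C1CC1)C(=O)OCc1ccccc1` differs from compound 3 in a single place: 1-hydroxyethyl in place of 4-((tert-butoxycarbonyl)amino)butyl on a saturated chain carbon bound to an amide-type nitrogen and a carbonyl carbon. The three measured steps all bear on this, since each of them exchanges the group on the same saturated chain carbon bound to an amide-type nitrogen and a carbonyl carbon, and none of them moved the read-out beyond the scatter even though the exchanged groups were very different in size. Nothing in these data suggests that a 1-hydroxyethyl group at this place should behave otherwise, so the expected step is a number 0.1 percentage points higher from compound 3 to compound 4 (within the scatter), not beyond the scatter. Compound 4 is therefore estimated at 33%, with a range from 18% to 48%.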

Compound 4, a percentage reported as activity, at one dose (the size of the read-out at that dose, not a potency): 23.4%
For compound 4 the middle estimate is 9.6 percentage points above the measured one, within the range that was stated.
By their numbers in this assay, from the lowest: compounds 4, 1, 3 and 2 (each within the scatter of the next, the first and the last beyond it).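

In this assay, among these compounds, the exchange of 1-hydroxyethyl for 2-carbamoylethyl on a saturated chain carbon bound to an amide-type nitrogen and a carbonyl carbon is the first at this place to carry the read-out past the scatter, as a number 14.4 percentage points lower from compound 2 to compound 4 (beyond the scatter) shows, so the group here can matter, though the effect is modest and rests on this single pair. The same 1-hydroxyethyl group cannot be told apart from the other two groups, since a number 9.5 percentage points lower from compound 3 to compound 4 (within the scatter) and a number 6.7 percentage points lower from compound 1 to compound 4 (within the scatter) are both too small to separate the compounds, and the large drop in heavy atoms on leaving 4-((tert-butoxycarbonyl)amino)butyl therefore has no readable consequence. Among the compounds shown here, nothing among the data gives a measurement that would account for the one step past the scatter.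

Going by these compounds, it stays open whether a hydroxymethyl group, the other stereoisomer of 1-hydroxyethyl, or a chain ending in a free amine or a carboxylic acid would stand with compound 2 or with compound 4 at this place. On these data alone, whether the difference between compound 2 and compound 4 holds at other doses or times also remains unknown from these compounds.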